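Swapping a methoxy for an amino group on the phenyl ring

A few compounds are considered here, and "the series" means these few. Any claim that something is new, unique, unknown or untested is made for them only; others in the source may bear on it.

Measured so far:
- compound 1 `Nc1ccccc1-c1cnc(C(=O)CCCCCCc2ccccc2)o1`: 750 nM
- compound 2 `COc1ccccc1-c1cnc(C(=O)CCCCCCc2ccccc2)o1`: 400 nM
- compound 3 `O=C(CCCCCCc1ccccc1)c1ncc(-c2ccccc2C(=O)C(F)(F)F)o1`: 5000 nM

In an assay (Rattus norvegicus) for inhibition of Fatty-acid amide hydrolase 1 (Homo sapiens) (on this read-out lower numbers stand for stronger inhibition and higher numbers for weaker inhibition), compound 2 gives the lowest of the three numbers. Compound 1, which carries an amino group in place of the methoxy, sits close by: the step of a 1.9-fold lower number from compound 1 to compound 2 (0.27 log units; within the scatter) is within the scatter, so no order between the two can be claimed. Compound 3, bearing a (trifluoromethyl)carbonyl group instead, is clearly weaker: a 13-fold higher number from compound 2 to compound 3 (1.10 log units; beyond the scatter) and a 6.7-fold higher number from compound 1 to compound 3 (0.82 log units; beyond the scatter).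

Compound 4 `Nc1cccc(-c2cnc(C(=O)CCCCCCc3ccccc3)o2)c1` has not yet been measured. Its change from compound 2 is 3-aminophenyl in place of 2-methoxyphenyl on an aromatic carbon. Among the compounds with values here, the step from compound 1 to compound 2 shows that amino and methoxy on this ring give numbers within the scatter of each other; no measured step covers a 3-aminophenyl group, so the position of the amino is uncharted. On that basis a step of about a 2.0-fold higher number from compound 2 to compound 4 (0.30 log units; within the scatter) in this assay is expected, with wide uncertainty. The estimate for compound 4 is 800 nM, within the range 250 nM to 2500 nM.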

Compound 4, inhibition constant: 19 nM
Beside the measured number, compound 4's estimate is 42-fold (1.62 log units) above it; measured number outside the range, below it.
By their numbers in this assay, from the lowest: compound 4; then compounds 2 and 1 (each within the scatter of the next); then compound 3.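

The place of the amino group on the phenyl ring matters far more than the earlier swaps could show: in this assay, 3-aminophenyl in place of 2-aminophenyl gives a 39-fold lower number from compound 1 to compound 4 (1.60 log units; beyond the scatter) with no change in the kind of group. The other new comparison, a 21-fold lower number from compound 2 to compound 4 (1.32 log units; beyond the scatter), is also large, but it changes the group and its place together, so it cannot separate the two. No measured evidence on the cause of this result is at hand.

From the compounds shown here alone, it remains open whether a methoxy group at the place the amino group holds in compound 4 would give a similarly low number, or whether the amino group itself is needed there. A hydroxyl group or a carboxylic acid at that place would test this further.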